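The source may hold more compounds than are shown below. What is called first, only, known or untested is meant among the compounds shown, and "the series" means these compounds.

Measured so far in an ADME assay on HepG2 cells (Homo sapiens) for cytotoxicity, read by luminescence, CellTiter-Glo and ATP content, with a stated time of 72 h; on this read-out lower numbers stand for an effect already at smaller amounts and higher numbers for an effect only at larger amounts of compound:
compound 1 `COc1ccc(F)cc1CNCCCNc1ccnc2cc(CCC(C)C)ccc12`: 890 nM
compound 2 `COc1ccc(F)cc1CNCCCNc1ccnc2cc(Cc3ccc(C#N)cc3)ccc12`: 6050 nM
compound 3 `COc1ccc(F)cc1CNCCCNc1ccnc2cc(-c3ccc(F)cc3)ccc12`: 770 nM

Compound 3 and compound 1 lie within the scatter of each other: a 1.2-fold lower number from compound 1 to compound 3 (0.06 log units; within the scatter). Compound 2 stands apart from both, with a 6.8-fold higher number from compound 1 to compound 2 (0.83 log units; beyond the scatter) and a 7.9-fold lower number from compound 2 to compound 3 (0.90 log units; beyond the scatter). All three share the same core and differ only in the group on the aromatic carbon of that core.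

Compound 4 `COc1ccc(F)cc1CNCCCNc1ccnc2cc(-c3ccccc3)ccc12` is not yet measured. It differs from compound 3 by hydrogen in place of fluoro on an aromatic carbon.

Among the compounds with values here, none of the measured steps touches a single substituent on the aryl group; each of them exchanges the whole group at that position. The step from compound 1 to compound 3, in which a 4-fluorophenyl replaced an isopentyl, stayed within the scatter, so even a large exchange at that position left this assay nearly unchanged, while the 4-cyanobenzyl of compound 2 moved the number well beyond it. Removing a single fluoro is a smaller change than either. The expectation is therefore no step beyond the scatter for a 1.1-fold higher number from compound 3 to compound 4 (0.04 log units; within the scatter). Compound 4 is expected to give about 850 nM in this assay, with a range from 400 nM to 1800 nM.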

Compound 4, half-maximal effective concentration: 2960 nM
Beside the measured number, compound 4's estimate is 3.5-fold (0.54 log units) below it; measured number outside the range, above it.
By their numbers in this assay, from the lowest: compounds 3 and 1 (each within the scatter of the next); then compound 4; then compound 2.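

In this assay the single fluoro para to a large group carries more weight than the earlier whole-group exchanges suggested: its loss gives a step beyond the scatter (a 3.8-fold higher number from compound 3 to compound 4 (0.58 log units; beyond the scatter)), whereas replacing isopentyl with 4-fluorophenyl stayed within it (a 1.2-fold lower number from compound 1 to compound 3 (0.06 log units; within the scatter)). An aryl group at this position therefore does not set the number by itself, since the unsubstituted phenyl separates both from the isopentyl group (a 3.3-fold higher number from compound 1 to compound 4 (0.52 log units; beyond the scatter)) and from the 4-cyanobenzyl group (a 2.0-fold lower number from compound 2 to compound 4 (0.31 log units; beyond the scatter)). Nothing available explains the effect of removing this fluoro.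

Still open, as far as these compounds go, is whether the lower number depends on fluoro itself or would also appear with chloro, methoxy or an amine in the same place on the phenyl ring. Also open, from the compounds shown here alone, is whether adding a fluoro to an unsubstituted benzyl group, or a longer chain ending in 4-fluorophenyl, would give a similar step, so the present result rests on a single pair of compounds.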